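This account rests on a few compounds, and the source may have more. Where it says the series, first, only, none or still open, it means among the compounds named here.

In a physicochemical assay, read by spectrophotometry, with a stated time of 30 min (on this read-out lower numbers stand for stronger inhibition and higher numbers for weaker inhibition), compound 3 (`COc1cc(/C=N/NC(=O)CCc2nc3ccccc3c(=O)[nH]2)ccc1O`) gives 204000000 nM. Compound 2 (`O=C(CCc1nc2ccccc2c(=O)[nH]1)N/N=C/c1ccc(Cl)cc1`) gives 381000000 nM, within the scatter of compound 3. Compound 1 (`COc1cc(/C=N/NC(=O)CCc2nc3ccccc3c(=O)[nH]2)cc(OC)c1OC`) gives 85000000 nM, a lower number that lies beyond the scatter from compound 3. Compound 3 thus sits in the upper pair of the three values, with compound 1 alone at the lower end.

The next structure is compound 4 (`COc1cc(/C=N/NC(=O)CCc2nc3ccccc3c(=O)[nH]2)cc(OC)c1O`), and the change is methoxy in place of hydrogen on an aromatic carbon, ortho to a hydroxy group.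

For the measured compounds named here, the only measured step between single-place analogues is a 1.9-fold lower number from compound 2 to compound 3 (0.27 log units; within the scatter), a swap of 4-chlorophenyl for 4-hydroxy-3-methoxyphenyl, and it stays within the scatter. Going by the values given here, no measured step adds a methoxy group alone, so this is a weak guide. Compound 1, whose aryl group bears methoxy groups and no hydroxy group, gives 85000000 nM, and that value tilts the expectation slightly towards lower numbers. A small move in that direction is therefore expected in this assay, not clearly beyond the scatter.

The expected size of the change is a 1.6-fold lower number from compound 3 to compound 4 (0.20 log units; within the scatter). For compound 4 the estimated value is 130000000 nM, with an expected range of 60000000 nM to 280000000 nM.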

Compound 4, half-maximal inhibitory concentration: 126000000 nM
Compound 4: the middle estimate sits 1.0-fold (0.01 log units) above what was measured; the measured number falls inside the stated range.
By their numbers in this assay, from the lowest: compounds 1, 4, 3 and 2 (each within the scatter of the next, the first and the last beyond it).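

Read in this assay, the methoxy group entering on the aromatic carbon, ortho to a hydroxy group, gives the first single-place reading at this position, and the step stays within the scatter (a 1.6-fold lower number from compound 3 to compound 4 (0.21 log units; within the scatter)). The second new step, hydrogen in place of methyl on an oxygen on an aromatic ring, isolates the hydroxy group against a methoxy group with the rest of the molecule unchanged, and it too stays within the scatter (a 1.5-fold higher number from compound 1 to compound 4 (0.17 log units; within the scatter)). For the compounds shown here, neither single change therefore shows a shift beyond the scatter, and compound 4 lies within the scatter of both compound 3 and compound 1, a link the earlier compounds could not provide.

No supporting measurement is available to explain the size of either step. Still open, on these data alone, is whether a different group on this aromatic carbon, such as an ethoxy group, an amine or a carboxylic acid, would carry the number beyond the scatter, and whether a methoxy group here would read the same with a chlorine atom in place of the hydroxy group.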